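This account rests on a few compounds, and the source may have more. Where it says the series, first, only, none or still open, it means among the compounds named here.

Within the data shown here, in a physicochemical assay for lipophilicity, read by HPLC, at pH 7.5 (on this read-out lower numbers stand for lower lipophilicity and higher numbers for higher lipophilicity), compound 2 `CN(CC(N)=O)c1c(C#N)c(-c2ccc(Br)cc2)nc2cnccc12` gives 2.1, the higher of the two numbers so far, as compound 1 `CC[C@@H](Nc1c(C#N)c(-c2ccc(Br)cc2)nc2cnccc12)C(=O)O` gives 1.6. Compound 3 `CC(C)(CC(N)=O)c1c(C#N)c(-c2ccc(Br)cc2)nc2cnccc12` differs from compound 2 by a group of 7 heavy atoms (5 carbon, 1 nitrogen, 1 oxygen; no ring) in place of a group of 6 heavy atoms (3 carbon, 2 nitrogen, 1 oxygen; no ring), on an aromatic carbon, on an aromatic carbon, ortho to a cyano group and opposite the ring nitrogen. Among the measured compounds shown here, the only measured step at this carbon is a number 0.50 log units higher from compound 1 to compound 2 (beyond the scatter), modest but beyond the scatter, and it involves a different exchange. On that single precedent, a modest upward change is expected, estimated as a number 0.60 log units higher from compound 2 to compound 3 (beyond the scatter). The estimated value for compound 3 is 2.7, with an expected range of 2.2 to 3.2.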

Compound 3, distribution coefficient: 2.1
Compound 3: the middle estimate sits 0.60 log units above what was measured, and the stated range ends above it.
By their numbers in this assay, from the lowest: compound 1; then compounds 2 and 3 (each within the scatter of the next).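

At this aromatic carbon, opposite the ring nitrogen, this assay shows no change at the digits printed from compound 2 to compound 3 (within the scatter), so the group of 7 heavy atoms reads the same as the (carbamoylmethyl)(methyl)amino group it replaces. Set against the (1-carboxypropyl)amino group, it gives a number 0.50 log units higher from compound 1 to compound 3 (beyond the scatter), a step of the same size as a number 0.50 log units higher from compound 1 to compound 2 (beyond the scatter). No measurement at hand explains these results. The compounds shown leave open how a simple amine, a hydroxyl group or a longer chain at this carbon would read.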